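The source may hold more compounds than are shown below. What is called first, only, known or untested is meant among the compounds shown, and "the series" means these compounds.

Working notes on the series.

Compound 1 `O=C(/C=C/c1ccccc1)OC1CC2(N3CCCC3)CC(c3ccccc3)C1C(c1ccccc1)C2` gives 3500 nM in an ADME assay on L6 cells (Rattus norvegicus) for cytotoxicity, with a stated time of 72 h; on this read-out higher numbers stand for weaker inhibition and lower numbers for stronger inhibition. Compound 2 `O=C(CN1CCCC1)OC1CC2(N3CCCC3)CC(c3ccccc3)C1C(c1ccccc1)C2` gives 42900 nM in this assay, and the step between them, a 12-fold higher number from compound 1 to compound 2 (1.09 log units; beyond the scatter), follows from the change ((pyrrolidin-1-yl)methyl in place of 2-phenylethenyl on a carbonyl carbon).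

Compound 3 `O=C(/C=C/c1ccccc1)OC1CC2(N3CCCCC3)CC(c3ccccc3)C1C(c1ccccc1)C2` gives 10500 nM in this assay; it differs from compound 1 by piperidin-1-yl in place of pyrrolidin-1-yl on a saturated ring carbon, and the step is a 3.0-fold higher number from compound 1 to compound 3 (0.48 log units; beyond the scatter). Compound 3 thus stands between compound 1 and compound 2 on this read-out.

Compound 4 `O=C(CN1CCCC1)OC1CC2(N3CCCCC3)CC(c3ccccc3)C1C(c1ccccc1)C2` has not yet been measured in this assay. It differs from compound 3 by (pyrrolidin-1-yl)methyl in place of 2-phenylethenyl on a carbonyl carbon. This is the same change as that from compound 1 to compound 2, made on the core of compound 3 rather than the core of compound 1; the surroundings of the place of change are the same in both pairs.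

For the measured compounds named here, for compound 4 the step from compound 3 is expected to be about a 9.5-fold higher number from compound 3 to compound 4 (0.98 log units; beyond the scatter), resting on the single earlier instance of this change, a 12-fold higher number from compound 1 to compound 2 (1.09 log units; beyond the scatter), with no second instance to check how far the step carries over to the other core. The estimate for compound 4 in this assay is 100000 nM, with a likely range from 40000 nM to 250000 nM.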

Compound 4, half-maximal inhibitory concentration: 16400 nM
For compound 4 the middle estimate is 6.1-fold (0.79 log units) above the measured one; the whole stated range lies above it.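

On the core of compound 3, (pyrrolidin-1-yl)methyl in place of 2-phenylethenyl gives a 1.6-fold higher number from compound 3 to compound 4 (0.19 log units; within the scatter) in this assay, so the large step seen on the core of compound 1 does not carry over at its earlier size: the same change on two cores in this assay, a 12-fold higher number (1.09 log units; beyond the scatter) from compound 1 to compound 2 and a 1.6-fold higher number (0.19 log units; within the scatter) from compound 3 to compound 4, 7.8-fold (0.89 log units) apart, beyond the scatter of two such steps

Read the other way round, piperidin-1-yl in place of pyrrolidin-1-yl gives a 2.6-fold lower number from compound 2 to compound 4 (0.42 log units; beyond the scatter), opposite in direction to the step seen with the 2-phenylethenyl ester: the same change on two cores in this assay, a 3.0-fold higher number (0.48 log units; beyond the scatter) from compound 1 to compound 3 and a 2.6-fold lower number (0.42 log units; beyond the scatter) from compound 2 to compound 4, 7.8-fold (0.89 log units) apart, beyond the scatter of two such steps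

The two changes therefore do not act independently in this set, and a step measured on one core cannot simply be transferred to the other, but a single set of four compounds does not show why they interact or how general this is.

Going by these compounds, it remains open whether the same dependence appears with another amine on the saturated ring carbon, such as morpholine or dimethylamine. On these data alone, it is also open whether it persists with a longer chain carrying the pyrrolidine on the carbonyl carbon.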